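Working notes on cytotoxicity across the urea series

The source may report more compounds than this note shows. Statements on the series, on what has been measured and on what is new or still open speak of the compounds shown alone.

Measured compounds:
Compound 1 `Cc1cn([C@@H]2C[C@H](O)[C@@H](CNC(=O)Nc3ccc(Cl)cc3)O2)c(=O)[nH]c1=O` — in an ADME assay on MRC5 cells (Homo sapiens) for cytotoxicity (a lower number here means that less compound is tolerated, a higher number that more compound is tolerated), compound 1 reports only the limit > 50000 nM.
Compound 2 `Cc1cn([C@@H]2C[C@H](O)[C@@H](CNC(=O)Nc3ccc(Cc4ccccc4)cc3)O2)c(=O)[nH]c1=O` — in this assay compound 2 reports only the limit > 50000 nM.
Compound 3 `Cc1cn([C@@H]2C[C@H](O)[C@@H](CNC(=O)Nc3ccc(OCc4cccc(Cl)c4)cc3)O2)c(=O)[nH]c1=O` — in this assay compound 3 reports only the limit > 50000 nM.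

Compound 3 thus stands at a limit, not a number, and the two companions sit at the same limit: the limit of > 50000 nM in this assay, at which 3 of the 3 values shown sit. Going by the values given here, the steps a step that the two limits leave unreadable from compound 1 to compound 2, a step that the two limits leave unreadable from compound 1 to compound 3 and a step that the two limits leave unreadable from compound 2 to compound 3 are all unreadable, so no measured step sets a size for the next move.

Compound 4 `COc1ccc(COc2ccc(NC(=O)NC[C@H]3O[C@H](n4cc(C)c(=O)[nH]c4=O)C[C@@H]3O)cc2)cc1` differs from compound 3 by 4-methoxyphenyl in place of 3-chlorophenyl on a saturated chain carbon bound to an oxygen on an aromatic ring. With every measured value at the limit, no readable step bears on this change, and compound 4 is expected to give the limit as well, an expected step that the limit leaves unreadable from compound 3 to compound 4. For compound 4 the estimate in this assay is 60000 nM, expected to lie between 25000 nM and 150000 nM.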

Compound 4, half-maximal cytotoxic concentration: > 50000 nM
Compound 4: a limit, no number (the forecaster's own chance of this, stated with the estimate: 85%); the middle value does not contradict the limit.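

Going by these compounds alone, compound 4 sits at the same limit as compound 1, compound 2 and compound 3, so no step to it can be read: the limit of > 50000 nM in this assay, at which 4 of the 4 values shown sit. Where these compounds lie in this assay as numbers, and whether any change on the shared core leaves the limit, stays open.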